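The source may report more compounds than this note shows. Statements on the series, on what has been measured and on what is new or still open speak of the compounds shown alone.

Three compounds sharing one core, and differing only in the group on a saturated chain carbon bound to a saturated ring carbon, have been measured in a functional assay on HUVEC cells (Homo sapiens), read by scintillation counting and thymidine incorporation, with a stated time of 24 h; on this read-out lower numbers stand for stronger inhibition and higher numbers for weaker inhibition. Compound 1 `CCC(C)n1ncn(-c2ccc(N3CCN(c4ccc(OC[C@@H]5CO[C@@](CBr)(c6ccc(Cl)cc6Cl)O5)cc4)CC3)cc2)c1=O`, carrying bromo, gives 569 nM. Compound 2 `CCC(C)n1ncn(-c2ccc(N3CCN(c4ccc(OC[C@@H]5CO[C@@](CN(C)C)(c6ccc(Cl)cc6Cl)O5)cc4)CC3)cc2)c1=O`, carrying dimethylamino, gives 1400 nM. Compound 3 `CCC(C)n1ncn(-c2ccc(N3CCN(c4ccc(OC[C@@H]5CO[C@@](Cn6ccnc6C(C)C)(c6ccc(Cl)cc6Cl)O5)cc4)CC3)cc2)c1=O`, carrying 2-isopropyl-1H-imidazol-1-yl, gives 84 nM, the lowest of the three numbers.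

Compound 4 `CCC(C)n1ncn(-c2ccc(N3CCN(c4ccc(OC[C@@H]5CO[C@@](Cn6cccn6)(c6ccc(Cl)cc6Cl)O5)cc4)CC3)cc2)c1=O` has 1H-pyrazol-1-yl in place of 2-isopropyl-1H-imidazol-1-yl at that same place: 1H-pyrazol-1-yl in place of 2-isopropyl-1H-imidazol-1-yl on a saturated chain carbon bound to a saturated ring carbon.

All three measured steps bear on this change, since each falls at this position. Bromo to the imidazolyl group gave a 6.8-fold lower number from compound 1 to compound 3 (0.83 log units; beyond the scatter), and dimethylamino to the imidazolyl group gave a 17-fold lower number from compound 2 to compound 3 (1.22 log units; beyond the scatter), while bromo to dimethylamino gave a 2.5-fold higher number from compound 1 to compound 2 (0.39 log units; beyond the scatter). Among the compounds with values here, the read-out therefore answers clearly to this group, but no measured compound carries a pyrazolyl group, and no step removes the isopropyl alone.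

With compound 3 at the low end of the measured range, a modest move toward a higher number is expected in this assay, though not one reaching the value of compound 2. The expected step is a 3.6-fold higher number from compound 3 to compound 4 (0.55 log units; beyond the scatter). For compound 4 the estimated value is 300 nM, with an expected range from 90 nM to 900 nM.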

Compound 4, half-maximal inhibitory concentration: 307 nM
The estimate for compound 4 lay 1.0-fold (0.01 log units) below the measured number, within the range that was stated.
By their numbers in this assay, from the lowest: compound 3; then compounds 4 and 1 (each within the scatter of the next); then compound 2.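

In this assay the 1H-pyrazol-1-yl group gave a 3.7-fold higher number from compound 3 to compound 4 (0.56 log units; beyond the scatter) even though both groups count as one five-membered aromatic ring with the same numbers of hetero atoms and hydrogen-bond acceptors, so having such a ring on this saturated chain carbon did not alone reproduce the number of compound 3. Replacing dimethylamino with 1H-pyrazol-1-yl still gave a 4.6-fold lower number from compound 2 to compound 4 (0.66 log units; beyond the scatter) and thus separated these two groups, whereas replacing bromo with 1H-pyrazol-1-yl gave a 1.9-fold lower number from compound 1 to compound 4 (0.27 log units; within the scatter) and leaves those two groups unresolved in this assay. No measurement accompanying these numbers accounts for any of these steps.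

The change from compound 3 to compound 4 alters both the ring and its isopropyl substituent, so the contribution of each remains unseparated. A plain 1H-imidazol-1-yl group would isolate the effect of the isopropyl, and a 1H-1,2,4-triazol-1-yl group or a 2-isopropyl-substituted ring bearing other hetero atoms would test how far the ring itself matters at this position.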